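Shortening the chain of compound 2

A few compounds are considered here, and "the series" means these few. Any claim that something is new, unique, unknown or untested is made for them only; others in the source may bear on it.

In a functional assay on MDA-MB-231 cells (Homo sapiens) for inhibition, read by MTT assay, with a stated time of 72 h (on this read-out lower numbers stand for stronger inhibition and higher numbers for weaker inhibition), compound 2 `Nc1nc2cc(-c3nn(CCCCCCCCCC(=O)NO)c4ncnc(N)c34)ccc2o1` gives > 50000 nM, which is a limit and not a number. Compound 2 therefore stands at the limit of > 50000 nM in this assay, at which 1 of the 3 values shown sits. Two related compounds give real numbers: compound 1 `Nc1nc2cc(-c3nn(CCCC(=O)NO)c4ncnc(N)c34)ccc2o1` gives 19500 nM, and compound 3 `Nc1ncnc2c1c(-c1cnc3[nH]ccc3c1)nn2CCCCCCCCCC(=O)NO` gives 10100 nM.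

Compound 4 `Nc1nc2cc(-c3nn(CCCCC(=O)NO)c4ncnc(N)c34)ccc2o1` keeps the core of compound 2 but has a much shorter chain: hydroxycarbamoyl in place of 5-(hydroxycarbamoyl)pentyl on a saturated chain carbon, four bonds along the chain from an aromatic nitrogen. In words, hydroxycarbamoyl takes the place of 5-(hydroxycarbamoyl)pentyl on a saturated chain carbon, four bonds along the chain from an aromatic nitrogen.

The most direct guide is an at least 2.5-fold higher number from compound 1 to compound 2 (0.40 log units; beyond the scatter), a change in the same chain on the same core, with the longer chain giving the higher number. The other measured change, an at least 4.9-fold lower number from compound 2 to compound 3 (0.69 log units; beyond the scatter), alters the aromatic group and leaves the chain untouched, so it says little about chain length. Among the measured compounds, the chain of compound 4 comes closest to that of compound 1, which gives 19500 nM.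

A move back toward lower numbers is therefore expected in this assay, and the estimated size is an at least 2.5-fold lower number from compound 2 to compound 4 (0.39 log units; beyond the scatter). For compound 4 the expected value is 20000 nM, with an estimated range from 8000 nM to 45000 nM.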

Compound 4, half-maximal inhibitory concentration: 21200 nM
For compound 4 the middle estimate is 1.1-fold (0.03 log units) below the measured one, within the range that was stated.
By their numbers in this assay, from the lowest: compounds 3, 1 and 4 (each within the scatter of the next, the first and the last beyond it). At a limit, above all of these: compound 2.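

In this assay the shorter chain gives an at least 2.3-fold lower number from compound 2 to compound 4 (0.37 log units; beyond the scatter), so the drop seen with compound 1 is not tied to that one chain but appears again with a second short chain on the same core. Between the two short chains the step is a 1.1-fold higher number from compound 1 to compound 4 (0.04 log units; within the scatter), so on this core, (hydroxycarbamoyl)methyl in place of hydroxycarbamoyl on that chain carbon makes no readable difference. Chain length therefore does not tell these two short chains apart, and the difference shows only when either is set against the much longer chain of compound 2, which goes against any simple rule that each added chain carbon changes the number.

As far as these compounds go, compound 2 is a limit and not a number, so the full size of its gap to the short chains stays open: the limit of > 50000 nM in this assay, at which 1 of the 4 values shown sits. Also open, from the compounds shown here alone, are where the number starts to rise for chains of intermediate length, whether a carboxylic acid or an amine at the chain end would give similar numbers in place of the hydroxycarbamoyl group, and what the aromatic group of compound 3 would give on a short chain.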